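The source may hold more compounds than are shown below. What is called first, only, known or untested is meant among the compounds shown, and "the series" means these compounds.

Within the data shown here, compound 1, `COc1ccc(C(=O)Nc2cc(Br)cc(C(F)(F)F)c2)cc1Nc1nccc(-c2cccnc2)n1`, is the only member of this small set with a number: in a functional assay on K562 cells (Homo sapiens) for antiproliferative activity, read by MTT assay, with a stated time of 48 h (a lower number here means a stronger inhibitor, a higher number a weaker inhibitor), compound 1 gives 215000 nM, a weak result. Among the measured compounds shown here, compound 2, `COc1ccc(C(=O)Nc2cccc(C(F)(F)F)c2)cc1Nc1nccc(-c2cccnc2)n1`, shares the same core but lacks the bromine; in this assay compound 2 gives "not determined" (no result reported), so compound 2 has no number to stand on, and no measured step anchors it. Compound 3, `COc1ccc(C(=O)Nc2cc(C(F)(F)F)cc(C(F)(F)F)c2)cc1Nc1nccc(-c2cccnc2)n1`, differs from compound 2 by trifluoromethyl in place of hydrogen on an aromatic carbon. With compound 2 unmeasured, no size or direction of step from compound 2 to compound 3 in this assay can be drawn from the numbers, and none beyond the scatter is assumed. The expectation for compound 3 rests instead on compound 1, which gives 215000 nM and carries a different group at the same place. Compound 3 is therefore expected to fall near 200000 nM, within a range of 40000 nM to 1000000 nM.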

Compound 3, half-maximal inhibitory concentration: 4840 nM
Estimate against measurement, compound 3: 41-fold (1.62 log units) above, and the stated range ends above it.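

In this assay, among these compounds, this position turns out to be sensitive to the group it carries: trifluoromethyl in place of bromo gives a 44-fold lower number from compound 1 to compound 3 (1.65 log units; beyond the scatter) and so a large change from one substitution on the shared core, something the single value of compound 1 could not show. From the compounds shown here alone, the step from compound 2 to compound 3 cannot be read, so the effect of adding either group to the unsubstituted ring remains unknown. Nothing available explains why trifluoromethyl and bromo differ so much here.

The compounds shown leave open how other groups would fare at this place, such as a chlorine atom, a methoxy group, an amine or a carboxylic acid. They also leave open whether the lower number would hold with a longer chain, such as a pentafluoroethyl group.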